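Chloro to Methyl in a Positive Allosteric Modulator Series

The compounds below may be only part of what the source reports. "The series", "measured", "known", "first", "only" and "open" are said of these compounds alone.

Of the compounds shown here, three have so far been tested in a functional assay on the whole organism for positive allosteric modulation, with Rattus norvegicus as the target; a higher number here means that more compound is needed for the effect, a lower number that less compound is needed. Compound 1 `Cc1nn(C)c2c1C(c1cccc(Cl)c1)=NCCN2CCCN(C)C` gave only a limit of the assay, > 10 mg/kg. Compound 2 `Cc1cccc(C2=NCCN(CCCN(C)C)c3c2c(C)nn3C)c1` likewise gave only a limit, > 10 mg/kg. For the measured compounds named here, compound 3 `Cc1nn(C)c2c1C(c1ccc(Cl)cc1)=NCCN2` is the one compound with a real number in this assay, namely 2.5 mg/kg; how its core differs from the core of compound 1 is not broken down here.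

The change from compound 1 to compound 2 is methyl in place of chloro on an aromatic carbon. Its size is a step that the two limits leave unreadable from compound 1 to compound 2, because both compounds sit at the limit of > 10 mg/kg in this assay, at which 2 of the 3 values shown sit.

Compound 4 `Cc1ccc(C2=NCCNc3c2c(C)nn3C)cc1` differs from compound 3 by methyl in place of chloro on an aromatic carbon. This is the same kind of change as from compound 1 to compound 2, but not the same: there the methyl sits meta to a large group, here para to a large group.

Since the measured pair yields no readable size, the expectation for compound 4 rests on compound 3 and its value of 2.5 mg/kg. The step is expected to be a 2.0-fold higher number from compound 3 to compound 4 (0.30 log units; within the scatter), modest in size. Compound 4 is therefore estimated at 5 mg/kg, most likely between 1.5 mg/kg and 10 mg/kg.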

Compound 4, minimum effective dose: 2.5 mg/kg
Beside the measured number, compound 4's estimate is 2.0-fold (0.30 log units) above it; measured number inside the range.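

In this assay, putting methyl in place of chloro, para to a large group, gives no change at the digits printed from compound 3 to compound 4 (within the scatter), so on the core of compound 3 the two groups cannot be told apart. The same swap on the core of compound 1 cannot be read, because neither compound there gives a real number, only a limit of the assay: the limit of > 10 mg/kg in this assay, at which 2 of the 4 values shown sit. The new step therefore does not show that the change carries from one core to the other, and the two pairs also differ in where the group sits on the aromatic ring, so a readable step on the core of compound 1 would still not be a clean comparison.

Still open, on these data alone, is whether a methoxy group or a carboxylic acid, para to a large group on the core of compound 3, would leave the number just as undisturbed. Also open, as far as these compounds go, is the size of the swap on the core of compound 1, where real numbers are still lacking.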